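The source may report more compounds than this note shows. Statements on the series, on what has been measured and on what is new or still open speak of the compounds shown alone.

Compound 1, `COc1ccc(-c2cn(C[C@H]3c4c(ccc(OS(=O)(=O)c5ccc(C)cc5)c4C)[C@@H]4CC[C@@]5(C)C[C@]43CC5=O)nn2)cc1`, carries a 4-methoxyphenyl group on its triazole and a tosylate on the aromatic ring of the shared core. In a functional assay on MCF7 cells (Homo sapiens) for cytotoxicity, read by MTT assay, with a stated time of 4 days (a lower number here means a stronger inhibitor, a higher number a weaker inhibitor), compound 1 gives only a limit of the assay, > 20000 nM, and no number; it sits at the limit of > 20000 nM in this assay, at which 1 of the 2 values shown sits. Going by the values given here, compound 2, `C=C1C(=O)[C@]23C[C@@]1(O)CC[C@H]2c1ccc(O)c(C)c1[C@@H]3Cn1cc(-c2ccc(OC)cc2)nn1`, differs from compound 1 in several places at once, and in this assay compound 2 gives 1710 nM; no single step connects the two, so their values are simply set side by side.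

Compound 3, `Cc1ccc(S(=O)(=O)Oc2ccc3c(c2C)[C@H](Cn2cc(-c4ccc(F)cc4)nn2)[C@@]24CC(=O)[C@@](C)(CC[C@@H]32)C4)cc1`, is reached from compound 1 by one change: fluoro in place of methoxy on an aromatic carbon. Among the compounds with values here, no measured step of this kind is available. A small substituent swap on the aryl group is expected to move the value little, so compound 3 is expected to stay near the limit, with a step that the limit leaves unreadable from compound 1 to compound 3. Compound 3 is therefore estimated at 25000 nM, within a range of 8000 nM to 80000 nM.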

Compound 3, half-maximal inhibitory concentration: > 20000 nM
Compound 3: a limit, no number; the forecaster's own chance of this, stated with the estimate: 70%; the middle value is on the limit's open side.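

In this assay compound 3 gives the limit > 20000 nM and no number. Going by these compounds alone, compound 1 also gives only a limit, so no step between compound 1 and compound 3 can be read: the limit of > 20000 nM in this assay, at which 2 of the 3 values shown sit. The compounds shown leave open whether methoxy and fluoro differ at all in this assay on this tosylate-bearing core.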